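A Cyano Group Enters an Unmeasured Scaffold

The source may report more compounds than this note shows. Statements on the series, on what has been measured and on what is new or still open speak of the compounds shown alone.

Compound 1: `Oc1ccc(CNc2cc(C(F)(F)F)cc3[nH]ncc23)c(Cl)c1`, 6020 nM
Compound 2: `O=[N+]([O-])c1cccc(CNc2cc(C(F)(F)F)cc3[nH]ncc23)c1`, > 100000 nM
Compound 3: `O=[N+]([O-])c1ccccc1CNc1cccc2[nH]ncc12`, "nd" (no result reported)

All three compounds were tested in an assay for inhibition of Indoleamine 2,3-dioxygenase 1 (Homo sapiens), with stated times of 10 min and 60 min; on this read-out lower numbers stand for stronger inhibition and higher numbers for weaker inhibition. Compound 1 gives a number, 6020 nM. For compound 2 the read-out is a limit of the assay rather than a number, > 100000 nM; this is the limit of > 100000 nM in this assay, at which 1 of the 3 values shown sits. For compound 3 no result was reported, so it stands nowhere on the numbers shown, and nothing can be said about how it compares with compound 1 or compound 2.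

Compound 4 is `N#Cc1cc(NCc2ccccc2[N+](=O)[O-])c2cn[nH]c2c1`. It differs from compound 3 by cyano in place of hydrogen on an aromatic carbon. Among the measured compounds shown here, no measured step between two compounds is available here, so neither the direction nor the size of any change beyond the usual scatter can be read from the data. Compound 4 is expected to give 25000 nM in this assay, with an estimated range from 3000 nM to 100000 nM.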

Compound 4, half-maximal inhibitory concentration: > 100000 nM
Compound 4 gave a limit, no number (the forecaster's own chance of this, stated with the estimate: 40%); middle value at least 4.0-fold (0.60 log units) from the limit.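

No step can be read from compound 3 to compound 4: compound 3 has no reported result, and compound 4 gives only a limit of the assay. The compounds shown leave open what cyano in place of hydrogen does to the result in this assay.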